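Fluoro on the Fused Ring: From Compound 3 to Compound 4

This account rests on a few compounds, and the source may have more. Where it says the series, first, only, none or still open, it means among the compounds named here.

In a functional assay on HeLa cells (Homo sapiens) for antiproliferative activity, read by MTT assay, with a stated time of 48 h (on this read-out lower numbers stand for stronger inhibition and higher numbers for weaker inhibition), the measured compounds stand as follows:
compound 1, `Cc1cnc(Nc2ccc(C(C)C)cc2)nc1Nc1nc2ccccc2s1`: > 50000 nM.
compound 2, `NS(=O)(=O)c1ccc(Nc2ncc(F)c(Nc3nc4ccccc4s3)n2)cc1`: 4520 nM.
compound 3, `Cc1cnc(Nc2ccc(S(N)(=O)=O)cc2)nc1Nc1nc2ccccc2s1`: 2800 nM.

The value of compound 1 is the limit of > 50000 nM in this assay, at which 1 of the 3 values shown sits, and not a number. Compound 3 and compound 2 lie within the scatter of each other, so neither is set above the other. The step of an at least 17-fold lower number from compound 1 to compound 3 (1.25 log units; beyond the scatter) is large, whereas a 1.6-fold lower number from compound 2 to compound 3 (0.21 log units; within the scatter) stays within the scatter. Compound 4, `Cc1cnc(Nc2ccc(S(N)(=O)=O)cc2)nc1Nc1nc2ccc(F)cc2s1`, differs from compound 3 by fluoro in place of hydrogen on an aromatic carbon. For the measured compounds named here, both measured steps alter the other aromatic ring, not the fused ring that carries this change, so no measured step bears on it directly. Compound 4 is therefore expected to show a 1.1-fold lower number from compound 3 to compound 4 (0.05 log units; within the scatter), a step not beyond the scatter. Compound 4 is estimated at 2500 nM, between 800 nM and 8000 nM.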

Compound 4, half-maximal inhibitory concentration: 3460 nM
Compound 4: middle estimate off by 1.4-fold (0.14 log units), on the low side; the range from low to high includes it.
By their numbers in this assay, from the lowest: compounds 3, 4 and 2 (each within the scatter of the next). At a limit, above all of these: compound 1.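

In this assay, for the compounds shown here, the fused ring, which no earlier step touched, now has a measured step of its own: a 1.2-fold higher number from compound 3 to compound 4 (0.09 log units; within the scatter). Compound 3 and compound 4 therefore cannot be told apart here, so this aromatic carbon accepts fluoro in place of hydrogen without a step beyond the scatter. Nothing among the evidence shown bears on this result. From the compounds shown here alone, whether an amine or a methoxy group on this same carbon would give a step beyond the scatter stays open. So does the outcome for fluoro on another carbon of the fused ring.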